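This account rests on a few compounds, and the source may have more. Where it says the series, first, only, none or still open, it means among the compounds named here.

Measured in a functional assay on DU-145 cells (Homo sapiens) for antiproliferative activity, read by MTT assay; a lower number here means a stronger inhibitor, a higher number a weaker inhibitor:
- compound 1 `Cc1nn2c(-c3nc4cc(Cl)c(Cl)cc4[nH]3)c(-c3ccccc3)nc2s1`: 19100 nM
- compound 2 `Cc1nn2c(-c3nc4cc(Cl)ccc4[nH]3)c(-c3ccccc3)nc2s1`: 25100 nM
- compound 3 `Cc1nn2c(-c3nc4cc(Cl)c(F)cc4[nH]3)c(-c3ccc(F)cc3)nc2s1`: > 30000 nM

Compound 3 gives no number, only a limit of the assay, > 30000 nM. Of the values in this small set, this is the limit of > 30000 nM in this assay, at which 1 of the 3 values shown sits.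

Compound 4 `Cc1nn2c(-c3nc4cc(Cl)c(F)cc4[nH]3)c(-c3ccccc3)nc2s1` is compound 3 with hydrogen in place of fluoro on an aromatic carbon, para to a large group, the change being 4-fluorophenyl to phenyl: hydrogen in place of fluoro on an aromatic carbon.

Within the data shown here, no measured step makes this change. Among the measured compounds shown here, the one measured step, a 1.3-fold higher number from compound 1 to compound 2 (0.12 log units; within the scatter), replaces a chloro rather than this fluoro, so it bears only loosely, as a sign that a single halogen swap need not move this assay beyond the scatter. Compound 1 and compound 2 carry the phenyl that compound 4 will have, and the nearest guide is compound 1 at 19100 nM with compound 2 at 25100 nM.

A small move toward a lower number is therefore expected, estimated as an at least 1.1-fold lower number from compound 3 to compound 4 (0.06 log units; that floor lies within the scatter). Another result reported only as a limit remains possible. For compound 4 the estimated value is 26000 nM, with an expected range of 14000 nM to 48000 nM.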

Compound 4, half-maximal inhibitory concentration: > 30000 nM
Compound 4: a limit, no number; the forecaster's own chance of this, stated with the estimate: 40%; middle value at least 1.1-fold (0.06 log units) away from the limit.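

In this assay compound 4, like compound 3, is reported only as a limit, so the step for the change from 4-fluorophenyl to phenyl cannot be read, and removing this fluoro does not bring a measurable number: the limit of > 30000 nM in this assay, at which 2 of the 4 values shown sit.

Compound 4 does give readable steps at the other halogen of the shared core, namely an at least 1.1-fold higher number from compound 2 to compound 4 (0.07 log units; that floor lies within the scatter) and an at least 1.5-fold higher number from compound 1 to compound 4 (0.19 log units; that floor lies within the scatter). Both are floors within the scatter, so fluoro at that place is not shown to differ from hydrogen or chloro, though the true steps may be larger.

As far as these compounds go, whether any change at the phenyl moves the number stays open, since neither fluoro nor hydrogen there yields a value. An amine or a carboxylic acid at that carbon of the phenyl would test this.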